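The source may hold more compounds than are shown below. What is called first, only, known or untested is meant among the compounds shown, and "the series" means these compounds.

Measured so far in an ADME assay on liver for metabolic stability, with Liver microsome (Rattus norvegicus) as the target, read by HPLC, using microsomes, with a stated time of 4 h; on this read-out higher numbers stand for fast clearance and lower numbers for slow clearance:
Compound 1 `COCCOc1cc2ncnc(-n3nc(-c4ccccn4)nc3N)c2cc1OCCOC`: < 11.7 mL/min/kg, a limit
Compound 2 `COCCOc1cc2c(-n3nc(-c4ccccn4)nc3N)ncnc2cc1OC`: < 11.7 mL/min/kg, a limit

Compound 2 has no number of its own: its < 11.7 mL/min/kg in this assay is a limit of the assay. Both measured compounds sit there, as the limit of < 11.7 mL/min/kg in this assay, at which 2 of the 2 values shown sit, shows.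

Compound 3 `COc1cc2ncnc(-n3nc(-c4ccccn4)nc3N)c2cc1OCCCNC(=O)OC(C)C` is reached from compound 2 by one change: ((isopropoxycarbonyl)amino)methyl in place of methoxy on a saturated chain carbon, two bonds along the chain from an oxygen on an aromatic ring. The 2-methoxyethoxy group thereby gives way to 3-((isopropoxycarbonyl)amino)propoxy.

Within the data shown here, one measured step bears on this, and it too alters a saturated chain carbon on the way to an oxygen on an aromatic ring: a step that the two limits leave unreadable from compound 1 to compound 2. No size can be taken from it, so the data offer no measured guide to how far this change moves the clearance. Only the larger entering group, as counted in the difference, suggests any movement, and that suggestion is weak. The estimated step is an at least 1.3-fold higher number from compound 2 to compound 3 (0.13 log units; that floor lies within the scatter), expected toward faster clearance and held with wide uncertainty.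

In this assay the estimate for compound 3 is 16 mL/min/kg, expected to fall between 8 mL/min/kg and 40 mL/min/kg.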

Compound 3, clearance: 45.1 mL/min/kg
Compound 3: middle estimate off by 2.8-fold (0.45 log units), on the low side; the whole stated range lies below it.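

With compound 3, this position gives its first readable result in this assay. Replacing 2-methoxyethoxy with 3-((isopropoxycarbonyl)amino)propoxy gives an at least 3.8-fold higher number from compound 2 to compound 3 (0.58 log units; beyond the scatter), a move toward faster clearance that shows this site is not indifferent to what it carries. The earlier step, from compound 1 to compound 2, cannot be read, so it offered no such sign, and compound 3 is the only one of the three compounds with a number of its own, which makes the new step a floor rather than a full size: the limit of < 11.7 mL/min/kg in this assay, at which 2 of the 3 values shown sit.

The compounds shown leave open which part of the entering group goes with the faster clearance: the longer chain, the amide hydrogen or the isopropyl ester end, since all of these arrive together in this single change. From the compounds shown here alone, a plain propoxy chain, a 3-aminopropoxy chain or a 3-acetamidopropoxy chain at the same place would begin to separate these parts, and how far compound 2 truly lies from compound 3 also remains open.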